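Trading a cyclobutyl amide for a trifluoromethylphenyl amide

A few compounds are considered here, and "the series" means these few. Any claim that something is new, unique, unknown or untested is made for them only; others in the source may bear on it.

Measured compounds:
- compound 1 `CN1CCC(C(=O)N2Cc3c(NC(=O)C4CCC4)n[nH]c3C2(C)C)CC1`: 140 nM
- compound 2 `CN1CCC(C(=O)N2Cc3c(NC(=O)c4ccco4)n[nH]c3C2(C)C)CC1`: > 5000 nM
- compound 3 `CN1CCN(C(=O)N2Cc3c(NC(=O)c4ccc(F)cc4)n[nH]c3C2(C)C)CC1`: 180 nM

In a functional assay on A2780 cells (Homo sapiens) for antiproliferative activity, read by fluorescence, with a stated time of 72 h (a lower number here means a stronger inhibitor, a higher number a weaker inhibitor), compound 1 gives 140 nM, the lowest number among the measured values. Compound 3 gives 180 nM, which sits within the scatter of compound 1. For compound 2 the result is only a limit, > 5000 nM, not a number.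

The new compound 4 `CN1CCC(C(=O)N2Cc3c(NC(=O)c4ccc(C(F)(F)F)cc4)n[nH]c3C2(C)C)CC1` is compound 1 with one change: 4-(trifluoromethyl)phenyl in place of cyclobutyl on a carbonyl carbon.

Within the data shown here, one measured step bears on this. Replacing cyclobutyl with an aromatic ring, furan-2-yl, gave an at least 35-fold higher number from compound 1 to compound 2 (1.55 log units; beyond the scatter), ending at the limit of > 5000 nM in this assay, at which 1 of the 3 values shown sits. Yet compound 3, which also carries an aromatic ring on a carbonyl carbon, stays close to compound 1, so an aromatic group at this position is not always ruinous. The 4-(trifluoromethyl)phenyl group is an all-carbon aromatic ring, closer to the ring of compound 3 than to the furan of compound 2, so a modest weakening beyond the scatter is expected, not a collapse.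

For compound 4 the estimate is 350 nM (range 80 nM to 3000 nM), an expected step of a 2.5-fold higher number from compound 1 to compound 4 (0.40 log units; beyond the scatter).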

Compound 4, half-maximal inhibitory concentration: 60 nM
Compound 4: middle estimate off by 5.8-fold (0.77 log units), on the high side, outside the stated range (below it).
By their numbers in this assay, from the lowest: compound 4; then compounds 1 and 3 (each within the scatter of the next). At a limit, above all of these: compound 2.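

In this assay, an aromatic ring on this carbonyl carbon can do better than cyclobutyl: 4-(trifluoromethyl)phenyl gives a 2.3-fold lower number from compound 1 to compound 4 (0.37 log units; beyond the scatter). The earlier furan-2-yl result therefore does not hold for every aromatic ring at this position, as the change from one ring to the other gives an at least 83-fold lower number from compound 2 to compound 4 (1.92 log units; beyond the scatter). That step starts from a limit and not from a number: the limit of > 5000 nM in this assay, at which 1 of the 4 values shown sits.

The compounds shown cannot separate the part played by the phenyl ring from that of the trifluoromethyl group; a plain phenyl amide, or a chlorine or a nitrile in place of trifluoromethyl, would address this. They also leave open how a ring carrying an amine or a carboxylic acid would behave here.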